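This account rests on a few compounds, and the source may have more. Where it says the series, first, only, none or still open, it means among the compounds named here.

Among the compounds with values here, compound 2, `Cc1ccc(F)cc1S(=O)(=O)N1CCN(c2ccc(C(=O)NCc3ccc(F)cc3)nn2)CC1`, stands highest of the two numbers so far in an ADME assay on microsomes from liver (Mus musculus) for metabolic stability, read by LC-MS, using NADPH, tested at 10 uM; on this read-out higher numbers stand for a longer-lived compound and lower numbers for a shorter-lived compound: compound 2 gives 1.13 h, while compound 1, `O=C(NCc1ccc(F)cc1)c1ccc(N2CCN(S(=O)(=O)c3cccnc3C3CC3)CC2)nn1`, gives 0.1 h. Within the data shown here, the one step known, an 11-fold higher number from compound 1 to compound 2 (1.05 log units; beyond the scatter), came from a change of the group on the sulfonyl sulfur. Compound 3, `O=C(NCc1ccc(F)cc1)c1ccc(N2CCN(S(=O)(=O)c3ccc(F)cc3C(F)(F)F)CC2)nn1`, changes that same position again: 4-fluoro-2-(trifluoromethyl)phenyl in place of 5-fluoro-2-methylphenyl on a sulfonyl sulfur. The known step does not describe this kind of exchange. It replaced a pyridine-based group with a phenyl group, whereas here one phenyl group is swapped for another that carries more fluorine. Among the measured compounds shown here, no measured pair therefore speaks directly to this step, and the expectation is a change close to or only modestly beyond the scatter, with compound 3 expected to sit near or somewhat above compound 2, estimated as a 1.4-fold higher number from compound 2 to compound 3 (0.15 log units; within the scatter). Compound 3 is thus expected to give 1.6 h, within 0.6 h to 4 h.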

Compound 3, half-life: 0.2 h
The estimate for compound 3 lay 8.0-fold (0.90 log units) above the measured number, outside the stated range (below it).
By their numbers in this assay, from the lowest: compounds 1 and 3 (each within the scatter of the next); then compound 2.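

In this assay, the group on the sulfonyl sulfur matters even when one substituted phenyl group replaces another: 4-fluoro-2-(trifluoromethyl)phenyl in place of 5-fluoro-2-methylphenyl gives a 5.7-fold lower number from compound 2 to compound 3 (0.75 log units; beyond the scatter). A phenyl group at this place is therefore not enough by itself to give a high number, which the earlier pair of compounds could not show. Replacing 2-cyclopropylpyridin-3-yl with the new phenyl group gives a 2.0-fold higher number from compound 1 to compound 3 (0.30 log units; within the scatter), so of the three groups, only 5-fluoro-2-methylphenyl stands clearly apart from the other two.

Nothing available explains these differences, and the compounds do not separate the exchange of methyl for trifluoromethyl from the move of fluorine from the 5- to the 4-position. A 4-fluoro-2-methylphenyl group on the sulfonyl sulfur, carrying only one of these two differences, remains an open case.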